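The source may hold more compounds than are shown below. What is called first, only, known or untested is meant among the compounds shown, and "the series" means these compounds.

In a physicochemical assay for solubility, with a stated time of 18 h, at pH 7.4 (a higher number here means a more soluble compound, a lower number a less soluble compound), compound 2 (`COc1ccc(Oc2ccc3c(NCCCNCc4cc(F)ccc4OC)ccnc3c2)cc1`) gives 14500 nM and compound 3 (`COc1cccc(Oc2ccc3c(NCCCNCc4ccco4)ccnc3c2)c1`) gives 14500 nM, together the lowest of the three numbers, while compound 1 (`Fc1ccc(-c2ccc3c(NCCCNCc4ccco4)ccnc3c2)cc1`) gives 32000 nM. Compound 2 therefore stands level with compound 3 and below compound 1.

The next compound to read is compound 4 (`CCC(CC)c1ccc2c(NCCCNCc3cc(F)ccc3OC)ccnc2c1`), where pentan-3-yl takes the place of 4-methoxyphenoxy on an aromatic carbon: pentan-3-yl in place of 4-methoxyphenoxy on an aromatic carbon.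

Among the measured compounds shown here, the one measured step that bears on this is a 2.2-fold lower number from compound 1 to compound 3 (0.34 log units; beyond the scatter), where 3-methoxyphenoxy replaces 4-fluorophenyl. Read in reverse, as a substituted phenoxy group leaves, it points to a modest rise in this assay of about that size. For the measured compounds named here, it is only a loose guide, as no measured compound carries pentan-3-yl and the entering group in compound 4 has no ring.

The estimated change is a 1.8-fold higher number from compound 2 to compound 4 (0.25 log units; within the scatter), a modest upward step with a wide margin. Compound 4 is expected at 26000 nM, with an estimated range of 11000 nM to 60000 nM.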

Compound 4, solubility: 4200 nM
Compound 4: middle estimate off by 6.2-fold (0.79 log units), on the high side; the whole stated range lies above it.
By their numbers in this assay, from the lowest: compound 4; then compounds 2 and 3 (each within the scatter of the next); then compound 1.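

Read in this assay, the change from 4-methoxyphenoxy to pentan-3-yl gives a 3.5-fold lower number from compound 2 to compound 4 (0.54 log units; beyond the scatter) and shows that a group with no ring, fewer heavy atoms and no hydrogen-bond acceptors does not bring a higher number at this position. The earlier step at this position, a 2.2-fold lower number from compound 1 to compound 3 (0.34 log units; beyond the scatter), had 3-methoxyphenoxy entering; here 4-methoxyphenoxy leaves and the number still falls, so a substituted phenoxy group does not act as a single downward term across these two steps. Nothing available explains the fall.

Still open, as far as these compounds go, is whether the drop follows the loss of the ring, the loss of the ether oxygen or the branched chain itself. A cyclohexyl group or a morpholine at this position would help separate these readings.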